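The source may hold more compounds than are shown below. What is called first, only, known or untested is meant among the compounds shown, and "the series" means these compounds.

Measured so far:
- compound 1, `C[C@@H](NC1CCN(CCCc2c[nH]c3ccc(-n4cnnc4)cc23)CC1)c1ccccc1`: 90% in a functional assay on CHO cells for activation of 5-hydroxytryptamine receptor 1D (Homo sapiens), read by GTPgammaS binding; a lower number here means a smaller maximal response, a higher number a larger maximal response
- compound 2, `c1ccc2c(c1)CCC2NCC1CCN(CCCc2c[nH]c3ccc(-n4cnnc4)cc23)CC1`: 78% in this assay

Within the data shown here, compound 2 stands lowest of the two values, with compound 1 above it by a number 12 percentage points lower from compound 1 to compound 2 (beyond the scatter), which is the only step at hand.

Compound 3, `c1cc(CNC2CCN(CCCc3c[nH]c4ccc(-n5cnnc5)cc34)CC2)co1`, carries ((furan-3-yl)methyl)amino in place of ((2,3-dihydro-1H-inden-1-yl)amino)methyl on a saturated ring carbon. The step from compound 1 to compound 2 exchanged one amine substituent for another and moved the response by a modest amount; the present change also replaces the amine substituent on the same saturated ring carbon, swapping the two-ring group for a single five-membered aromatic ring with 1 hetero atom. Among the measured compounds shown here, no measured step covers this kind of exchange, so the only guide is that a prior substituent swap at this position shifted the maximal response modestly.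

For compound 3 a step of about a number 2 percentage points higher from compound 2 to compound 3 (within the scatter) in this assay is expected, most likely within the scatter, with the estimate at 80% and a range from 62% to 95%.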

Compound 3, largest response reached (reported as efficacy), in percent of the reference or control that the assay uses: 65%
Compound 3: middle estimate off by 15 percentage points, on the high side; measured number inside the range.
By their numbers in this assay, from the lowest: compound 3; then compound 2; then compound 1.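

In this assay, the amine substituent on this saturated ring carbon proves able to lower the maximal response further, with ((furan-3-yl)methyl)amino giving a number 13 percentage points lower from compound 2 to compound 3 (beyond the scatter) in a second swap at this place. Measured against the 1-phenylethyl group on the amine nitrogen, (furan-3-yl)methyl gives a number 25 percentage points lower from compound 1 to compound 3 (beyond the scatter) and the widest gap among the three compounds, leaving compound 3 lowest. Nothing measured here accounts for these shifts.

The compounds shown do not separate the effect of the furan oxygen from that of replacing a carbon-only aromatic ring with a five-membered one. A benzyl or (thiophen-3-yl)methyl group on the same amine nitrogen would help to separate the two, and a (furan-2-yl)methyl group would show whether the furan attachment point matters.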